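From a Chlorophenyl to a Trifluoromethylphenyl Amine

This account rests on a few compounds, and the source may have more. Where it says the series, first, only, none or still open, it means among the compounds named here.

Going by the values given here, compound 2 `C=CC(=O)Nc1cccc(NC(=O)CSc2nc(Nc3cccc(Cl)c3)c3ccccc3n2)c1` gives 7830 nM in a functional assay on MGC-803 cells (Homo sapiens) for inhibition, read by MTT assay, with a stated time of 72 h (a higher number here means a weaker inhibitor, a lower number a stronger inhibitor), the lowest of the two numbers measured so far; compound 1 `C=CC(=O)Nc1cccc(NC(=O)CSc2nc(Nc3ccccc3F)c3ccccc3n2)c1` gives 26100 nM. Their sole difference, in the aryl group on the amine nitrogen, produced a 3.3-fold lower number from compound 1 to compound 2 (0.52 log units; beyond the scatter). Compound 3 `C=CC(=O)Nc1cccc(NC(=O)CSc2nc(Nc3ccc(C(F)(F)F)cc3)c3ccccc3n2)c1` is not yet measured; it differs from compound 2 by 4-(trifluoromethyl)phenyl in place of 3-chlorophenyl on a nitrogen on an aromatic ring. Among the compounds with values here, that single measured step is the only guide, and it concerns the same aryl group, so a modest shift in either direction is plausible but not assured. Compound 3 is therefore expected near 8000 nM, within 2500 nM to 25000 nM, an expected step of a 1.0-fold higher number from compound 2 to compound 3 (0.01 log units; within the scatter).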

Compound 3, half-maximal inhibitory concentration: 12100 nM
Beside the measured number, compound 3's estimate is 1.5-fold (0.18 log units) below it; the measured number falls inside the stated range.
By their numbers in this assay, from the lowest: compounds 2 and 3 (each within the scatter of the next); then compound 1.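

At this aryl group on the amine nitrogen, a 1.5-fold higher number from compound 2 to compound 3 (0.19 log units; within the scatter) in this assay, so 4-(trifluoromethyl)phenyl and 3-chlorophenyl cannot be told apart here. Replacing 2-fluorophenyl with 4-(trifluoromethyl)phenyl gives a 2.2-fold lower number from compound 1 to compound 3 (0.33 log units; beyond the scatter), so two different aryl groups now stand clear of compound 1, each by a modest step. Nothing available explains these numbers. Still open, on these data alone, is whether a phenyl ring carrying an amine or a carboxylic acid, or a short alkyl chain in place of the ring, would hold this level.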